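Three Analogues at the Limit, a Fourth Expected to Follow

The source may hold more compounds than are shown below. What is called first, only, known or untested is meant among the compounds shown, and "the series" means these compounds.

Compound 1 `Cc1ccc(-c2n[nH]cc2N2CCCNCC2)cc1` gives > 10000 nM in an assay on isolated protein for binding affinity to 5-hydroxytryptamine receptor 1E (Homo sapiens) (a higher number here means a weaker inhibitor, a lower number a stronger inhibitor), a limit of the assay and not a number.
Compound 2 `Fc1cccc(-c2n[nH]cc2N2CCCNCC2)c1` gives > 10000 nM in this assay, again a limit.
Compound 3 `COc1cccc(-c2n[nH]cc2N2CCCNCC2)c1` gives > 10000 nM in this assay, also a limit.

Compound 3 therefore stands nowhere on a scale of numbers: its result in this assay is a limit, as are the two further values shown, so no order among compounds 1, 2 and 3 can be read from them. Among the measured compounds shown here, the one step between compounds that differ in a single place, a step that the two limits leave unreadable from compound 2 to compound 3, is unreadable for the same reason, and the one thing the measurements do establish, (the limit of > 10000 nM in this assay, at which 3 of the 3 values shown sit), is that all three values sit at the same limit.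

The unmeasured compound 4 `c1ccc(-c2n[nH]cc2N2CCCNCC2)cc1` differs from compound 3 by hydrogen in place of methoxy on an aromatic carbon. For the measured compounds named here, none of the measured steps gives a readable size that bears on this change; what the three values show is that removing or swapping a small group on this ring has not brought any compound below the limit. Compound 4 is therefore expected to give 15000 nM in this assay, with a range from 4000 nM to 60000 nM, and the expected step that the limit leaves unreadable from compound 3 to compound 4 is one that the limit would most likely leave unreadable.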

Compound 4, inhibition constant: > 10000 nM
Compound 4 gave a limit, no number; the forecaster's own chance of this, stated with the estimate: 85%; the middle value does not contradict the limit.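

The steps from compound 1, compound 2 and compound 3 to compound 4 cannot be read in this assay, and all four results are limits: the limit of > 10000 nM in this assay, at which 4 of the 4 values shown sit. The compounds shown leave open how these four compare and whether any other change to the shared core would give a measurable value.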